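From methoxy to trifluoromethoxy on the shared core

The source may report more compounds than this note shows. Statements on the series, on what has been measured and on what is new or still open speak of the compounds shown alone.

Measured in a functional assay on PBMC cells (Homo sapiens) for inhibition, read by HTRF, with stated times of 15 min and 24 h; on this read-out lower numbers stand for stronger inhibition and higher numbers for weaker inhibition:
compound 1 `O=C(Nc1ccc2c(c1)B(O)OC2)c1ccccc1C(F)(F)F`: 4400 nM
compound 2 `O=C(Nc1ccc2c(c1)B(O)OC2)c1ccccc1`: > 100000 nM (a limit)
compound 3 `COc1ccccc1C(=O)Nc1ccc2c(c1)B(O)OC2`: > 100000 nM (a limit)

Compound 3 has no number, only the limit > 100000 nM in this assay, the same limit that holds for compound 2. Compound 4 `O=C(Nc1ccc2c(c1)B(O)OC2)c1ccccc1OC(F)(F)F` carries trifluoromethyl in place of methyl on an oxygen on an aromatic ring, so methoxy becomes trifluoromethoxy.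

Among the compounds with values here, no measured step makes this exact change. The closest are an at least 22-fold higher number from compound 1 to compound 3 (1.35 log units; beyond the scatter) and an at least 22-fold higher number from compound 1 to compound 2 (1.35 log units; beyond the scatter), both large and beyond the scatter. The step that the two limits leave unreadable from compound 2 to compound 3 adds nothing to this. A large step towards lower numbers is therefore expected in this assay because an at least 22-fold higher number from compound 1 to compound 3 (1.35 log units; beyond the scatter) links the fluorinated group of compound 1 to a number, although compound 4 could also stay at the limit. The expected change is an at least 12-fold lower number from compound 3 to compound 4 (1.09 log units; beyond the scatter) as an estimate. For compound 4 the estimated value is 8000 nM, with an expected range from 1500 nM to 60000 nM in this assay.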

Compound 4, half-maximal inhibitory concentration: > 100000 nM
Compound 4: no number, only a limit (the forecaster's own chance of this, stated with the estimate: 25%); at least 12-fold (1.09 log units) between middle value and limit.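

In this assay, putting trifluoromethoxy in place of trifluoromethyl on an aromatic carbon gives an at least 22-fold higher number from compound 1 to compound 4 (1.35 log units; beyond the scatter), so the fluorines of trifluoromethoxy do not bring the measurable inhibition that trifluoromethyl gives in compound 1. The steps linking compound 4 to compound 2 and to compound 3 cannot be read, and the change from methoxy to trifluoromethoxy therefore shows no measurable gain in this assay. Among the groups shown at this place, only the trifluoromethyl of compound 1 gives a number, and the other three compounds share one ceiling: the limit of > 100000 nM in this assay, at which 3 of the 4 values shown sit.

As far as these compounds go, how far compound 2, compound 3 and compound 4 lie beyond that limit remains open. Also open, from the compounds shown here alone, is whether a chlorine, a nitrile or a longer fluorinated chain such as pentafluoroethyl on the same aromatic carbon would give a number, and how it would compare with compound 1.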